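This account rests on a few compounds, and the source may have more. Where it says the series, first, only, none or still open, it means among the compounds named here.

Compound 1, whose structure is `CCCCCCCCCO[C@@H]1[C@@H](N)[C@@H](OCC(O)CNCCO)O[C@H](CN)[C@H]1OCCCCCCCCC`, was tested in a toxicity assay on the whole organism (J774 cells) for cytotoxicity, with Mus musculus as the target, read by MTT assay, with a stated time of 24 h, tested at 30 uM (a higher number here means a weaker effect of the compound at the concentration tested, a lower number a stronger effect), where compound 1 gives 10.1%. Among the measured compounds shown here, this is the lower of the two numbers measured so far. The other measured compound, compound 2 `C=CCO[C@H]1O[C@H](CN)[C@@H](OCc2ccc3ccccc3c2)[C@H](OCc2ccc3ccccc3c2)[C@H]1N`, gives 28.3% in this assay, a value that lies beyond the usual scatter above that of compound 1; as these two compounds differ in more than one place, their pair says nothing about any single change.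

Compound 3 `CCCCCCCCCO[C@@H]1[C@@H](N)[C@@H](OC[C@H](O)CN)O[C@H](CN)[C@H]1OCCCCCCCCC` has not yet been measured. It differs from compound 1 in one place: 2-amino-1-hydroxyethyl in place of 1-hydroxy-2-((2-hydroxyethyl)amino)ethyl on a saturated chain carbon bound to an oxygen on a saturated carbon. The rest of the molecule stays the same. For the measured compounds named here, no measured pair isolates this change, so its effect can only be estimated. The step is expected to be small, a number 2.9 percentage points higher from compound 1 to compound 3 (within the scatter), and may well lie within the usual scatter. For compound 3 the value is estimated at 13%, within a range from 3% to 28%.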

Compound 3, a percentage reported as activity, at one concentration (the size of the read-out at that concentration, not a potency): 14.4%
For compound 3 the middle estimate is 1.4 percentage points below the measured one, and the stated range covers the measured number.
By their numbers in this assay, from the lowest: compounds 1 and 3 (each within the scatter of the next); then compound 2.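

In this assay, putting 2-amino-1-hydroxyethyl in place of 1-hydroxy-2-((2-hydroxyethyl)amino)ethyl on this saturated chain carbon gives a number 4.3 percentage points higher from compound 1 to compound 3 (within the scatter). Among the compounds shown here, this is the first pair here that isolates a single change, and the read-out does not separate the two groups, so at this position, on the core of compound 1, the hydroxyethyl on the nitrogen can be absent without a difference beyond the scatter. Nothing available explains this result.

Only these two side chains have been compared at this position, so one pair cannot show how much change the position accepts in general. On these data alone, how a carboxylic acid or a plain hexyl chain in place of 3-amino-2-hydroxypropyl would read in this assay remains open.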